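The compounds below may be only part of what the source reports. "The series", "measured", "known", "first", "only" and "open" are said of these compounds alone.

Compound 3 `C/C=C/C(=O)Nc1cccc(Cn2nc(-c3ccc(Oc4ccccc4)cc3)cc2C(=O)OCC)c1` gives 14200 nM in a functional assay on Maver1 cells (Homo sapiens) for inhibition, read by luminescence and CellTiter-Glo, with a stated time of 72 h (on this read-out lower numbers stand for stronger inhibition and higher numbers for weaker inhibition), the highest of the two plain numbers in this set. Compound 1 `CCOC(=O)c1cc(-c2ccc(Oc3ccccc3)cc2)nn1Cc1cccc(NC(=O)CCl)c1` gives 500 nM, and the step of a 28-fold higher number from compound 1 to compound 3 (1.45 log units; beyond the scatter) is large. Compound 2 `C/C=C/C(=O)Nc1ccc(Cn2nc(-c3ccc(Oc4ccccc4)cc3)cc2C(=O)OCC)cc1` reaches only a limit of the assay, > 60000 nM, and the step of an at least 4.2-fold lower number from compound 2 to compound 3 (0.62 log units; beyond the scatter) is at least modest. Compound 4 `C=CC(=O)Nc1cccc(Cn2nc(-c3ccc(Oc4ccccc4)cc3)cc2C(=O)OCC)c1` has not yet been measured; it differs from compound 3 by vinyl in place of prop-1-en-1-yl on a carbonyl carbon. Going by the values given here, of the measured steps, only the one from compound 1 to compound 3 touches this position, and it showed that exchanging the group on the carbonyl carbon moved the number far, while the pattern of the bearing ring was kept. The new group is shorter by one carbon and keeps the double bond outside aromatic rings. Among the compounds with values here, a step toward a lower number is expected, of moderate size but with wide uncertainty, as no measured pair shows this exact exchange. Compound 4 is therefore estimated at 2000 nM, within 400 nM to 10000 nM, which would mean a step of a 7.1-fold lower number from compound 3 to compound 4 (0.85 log units; beyond the scatter).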

Compound 4, half-maximal inhibitory concentration: 8600 nM
Beside the measured number, compound 4's estimate is 4.3-fold (0.63 log units) below it, and the stated range covers the measured number.
By their numbers in this assay, from the lowest: compound 1; then compounds 4 and 3 (each within the scatter of the next). At a limit, above all of these: compound 2.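

Exchanging prop-1-en-1-yl for vinyl on the carbonyl carbon gives a 1.7-fold lower number from compound 3 to compound 4 (0.22 log units; within the scatter) in this assay, so the extra carbon of prop-1-en-1-yl makes no difference that this read-out can resolve. Vinyl, like prop-1-en-1-yl, stays well apart from chloromethyl at this position, with a 17-fold higher number from compound 1 to compound 4 (1.24 log units; beyond the scatter), so among these three groups the large change belongs to chloromethyl alone. The step of an at least 6.9-fold lower number from compound 2 to compound 4 (0.84 log units; beyond the scatter) is only a bound, and the number it starts from is a limit of the assay: the limit of > 60000 nM in this assay, at which 1 of the 4 values shown sits.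

As far as these compounds go, whether a bromomethyl group or a longer chain on this carbonyl carbon would come closer to the number of compound 1 stays open. The compounds shown also leave open how a carboxylic acid in place of the ethyl ester would read.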